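Swapping Fluoro for Cyano on a Weak Channel Inhibitor

A few compounds are considered here, and "the series" means these few. Any claim that something is new, unique, unknown or untested is made for them only; others in the source may bear on it.

Measured so far:
compound 1 `CN(Cc1ccc(OCCCN)cc1)c1nc2ccc(Oc3ccc(F)cc3)cc2s1`: 98000 nM
compound 2 `NCCCOc1ccc(CNc2nc3ccc(Oc4cccc(C(F)(F)F)c4)cc3s2)cc1`: 144000 nM
compound 3 `N=C(N)NCCCOc1ccc(CNc2nc3ccc(Oc4ccc(O)cc4)cc3s2)cc1`: 253000 nM

In an assay on SH-SY5Y cells for inhibition of Voltage-dependent N-type calcium channel subunit alpha-1B (Homo sapiens), read by FLIPR and calcium flux, with stated times of 600 s and 300 s, in the presence of a further agent that is not named here (on this read-out higher numbers stand for weaker inhibition and lower numbers for stronger inhibition), compound 1 shows the lowest of the three numbers. The number for compound 2 lies within the scatter of it, so the two cannot be told apart, while compound 3 sits beyond the scatter with a higher number. Compound 4 `CN(Cc1ccc(OCCCN)cc1)c1nc2ccc(Oc3ccc(C#N)cc3)cc2s1` has not yet been measured. It differs from compound 1 in a single place: cyano in place of fluoro on an aromatic carbon. Within the data shown here, no measured pair shows this exact change, so there is no measured step to lean on. A step no larger than the scatter, in either direction, is expected from a 1.0-fold higher number from compound 1 to compound 4 (0.01 log units; within the scatter). Compound 4 is therefore estimated at 100000 nM, within a range from 40000 nM to 250000 nM.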

Compound 4, half-maximal inhibitory concentration: 65000 nM
Beside the measured number, compound 4's estimate is 1.5-fold (0.19 log units) above it, within the range that was stated.
By their numbers in this assay, from the lowest: compounds 4, 1, 2 and 3 (each within the scatter of the next, the first and the last beyond it).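

In this assay the change from 4-fluorophenoxy to 4-cyanophenoxy gives a 1.5-fold lower number from compound 1 to compound 4 (0.18 log units; within the scatter) and so compound 1 and compound 4 cannot be told apart. Among these compounds, this is the only direct reading of a single change at this place, an aromatic carbon para to a large group, and here a nitrile can stand in for fluorine without a step beyond the scatter. Nothing measured here explains this result.

As far as these compounds go, whether an amine or a carboxylic acid at this same place would shift the number beyond the scatter remains open.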